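A few compounds are considered here, and "the series" means these few. Any claim that something is new, unique, unknown or untested is made for them only; others in the source may bear on it.

In an ADME assay on MT4 cells (Homo sapiens) for cytotoxicity, read by MTT assay, with a stated time of 96 h (a lower number here means that less compound is tolerated, a higher number that more compound is tolerated), the three measured compounds stand as follows:

Compound 1, `Cc1ccc(NCc2cn(-c3ccccc3)nc2-c2ccc(Cl)cc2)cc1`, gives > 100000 nM, which is a limit of the assay.
Compound 2, `Cc1ccc(NCc2cn(-c3ccccc3)nc2-c2ccc(C(F)(F)F)cc2)cc1`, gives > 100000 nM, which is a limit of the assay.
Compound 3, `Cc1ccc(-c2nn(-c3ccccc3)cc2CNc2ccc(C(F)(F)F)cc2)cc1`, gives > 100000 nM, which is a limit of the assay.

Compound 1 and compound 2 share a core and differ by chloro in place of trifluoromethyl on an aromatic carbon. The step that the two limits leave unreadable from compound 2 to compound 1 cannot be read, since both ends are limits; all that the pair shows is that neither compound reaches a measurable value. Compound 3 carries the same atoms as compound 2, joined differently; the difference between the two cores is not broken down here.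

Compound 4, `Cc1ccc(-c2nn(-c3ccccc3)cc2CNc2ccc(Cl)cc2)cc1`, has not been measured. It is related to compound 3 by chloro in place of trifluoromethyl on an aromatic carbon, the same change that carries compound 2 to compound 1. For the measured compounds named here, the only evidence on that change is the limit of > 100000 nM in this assay, at which 3 of the 3 values shown sit, and it gives no readable size for any step. What the data lack is any value below the limit for the shared core or for either aryl group.

For compound 4 a step that the limit leaves unreadable from compound 3 to compound 4 is therefore expected, resting on compound 3 at > 100000 nM and on the unreadable step from compound 2 to compound 1. Compound 4 is estimated to give 150000 nM in this assay, with a range from 60000 nM to 400000 nM, and the most likely outcome is that only a limit is reported again.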

Compound 4, half-maximal cytotoxic concentration: > 100000 nM
Compound 4 ended at the assay's limit; the forecaster's own chance of this, stated with the estimate: 85%; the middle value is on the limit's open side.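

In this assay compound 4 gives > 100000 nM, which is a limit of the assay. For the compounds shown here, with compound 3 also at a limit, the change from 4-(trifluoromethyl)phenyl to 4-chlorophenyl between compound 3 and compound 4 has no readable size, and the only evidence is this: the limit of > 100000 nM in this assay, at which 4 of the 4 values shown sit. The compounds shown leave open what change to the cores or aryl groups, if any, would give a readable value.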